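From compound 3 to compound 4: adding one methoxy

The source may report more compounds than this note shows. Statements on the series, on what has been measured and on what is new or still open speak of the compounds shown alone.

Values measured in a functional assay on DLA cells (Mus musculus) for cytotoxicity, read by LDH release, with a stated time of 48 h; a lower number here means a stronger inhibitor, a higher number a weaker inhibitor:
- compound 1 `Cc1cc(C(=O)c2ccccc2)ccc1OCC(=O)Nc1nc(-c2ccccc2)cs1` gives 23000 nM
- compound 2 `COc1ccc(-c2csc(NC(=O)COc3ccc(C(=O)c4ccccc4)cc3C)n2)cc1` gives 26200 nM
- compound 3 `Cc1cc(C(=O)c2ccccc2)cc(C)c1OCC(=O)Nc1nc(-c2ccccc2)cs1` gives 19900 nM

In this assay compound 3 gives 19900 nM and lies within the scatter of both other compounds, so the three values set no order. Compound 4 `COc1ccc(-c2csc(NC(=O)COc3c(C)cc(C(=O)c4ccccc4)cc3C)n2)cc1` has yet to be measured. It differs from compound 3 by a single change: methoxy in place of hydrogen on an aromatic carbon. This is methoxy in place of hydrogen on an aromatic carbon, or phenyl to 4-methoxyphenyl. The same exchange has been measured once, as a 1.1-fold higher number from compound 1 to compound 2 (0.06 log units; within the scatter), which lies within the scatter. The other measured step, methyl in place of hydrogen, is a 1.2-fold lower number from compound 1 to compound 3 (0.06 log units; within the scatter) and also lies within the scatter. Resting on that single precedent, no step beyond the scatter is expected in this assay, and the direction stays open. The expected step is a 1.1-fold higher number from compound 3 to compound 4 (0.05 log units; within the scatter), a small one. For compound 4 the estimated value is 22500 nM, with an expected range from 14000 nM to 36000 nM as its limits.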

Compound 4, half-maximal inhibitory concentration: 40100 nM
Compound 4: the middle estimate sits 1.8-fold (0.25 log units) below what was measured; the whole stated range lies below it.
By their numbers in this assay, from the lowest: compounds 3, 1, 2 and 4 (each within the scatter of the next).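

In this assay the change from phenyl to 4-methoxyphenyl now has a second reading on another core, a 2.0-fold higher number from compound 3 to compound 4 (0.30 log units; within the scatter), and the two readings agree within the scatter: the same change on two cores in this assay, a 1.1-fold higher number (0.06 log units; within the scatter) from compound 1 to compound 2 and a 2.0-fold higher number (0.30 log units; within the scatter) from compound 3 to compound 4, 1.8-fold (0.25 log units) apart, within the scatter of two such steps.
Methyl in place of hydrogen also has a second reading, a 1.5-fold higher number from compound 2 to compound 4 (0.18 log units; within the scatter), which likewise agrees with the first: the same change on two cores in this assay, a 1.2-fold lower number (0.06 log units; within the scatter) from compound 1 to compound 3 and a 1.5-fold higher number (0.18 log units; within the scatter) from compound 2 to compound 4, 1.8-fold (0.25 log units) apart, within the scatter of two such steps.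
Neither change has yet moved the number beyond the scatter on either core, so the result adds a second core for each change but still sets no order among the four compounds.

The compounds shown carry only hydrogen or methoxy at this place on the ring, so what an amine or a carboxylic acid there would do in this assay stays open.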